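This account rests on a few compounds, and the source may have more. Where it says the series, first, only, none or still open, it means among the compounds named here.

In a functional assay on HeLa cells (Homo sapiens) for cytotoxicity, read by ELISA, with a stated time of 2 days (on this read-out lower numbers stand for stronger inhibition and higher numbers for weaker inhibition), compound 1 (`Oc1cccc(-c2cc(-c3ccccc3)cc(-c3ccsc3)n2)c1`) gives 13800 nM and compound 3 (`Oc1cccc(-c2cc(-c3ccccc3)cc(-c3cccc(O)c3)n2)c1`) gives 13000 nM. The measured step of a 1.1-fold lower number from compound 1 to compound 3 (0.03 log units; within the scatter) leaves these two level. Compound 2 (`Oc1cccc(-c2cc(-c3ccccc3)cc(-c3ccncc3)n2)c1`) gives 28100 nM, the highest number of the three, and a 2.0-fold higher number from compound 1 to compound 2 (0.31 log units; beyond the scatter) shows that compound 1 lies a modest distance from it.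

Compound 4 (`Oc1ccc(-c2cc(-c3ccccc3)cc(-c3ccsc3)n2)cc1`) has not yet been measured. It differs from compound 1 in a single group: 4-hydroxyphenyl in place of 3-hydroxyphenyl on an aromatic carbon. In words, 4-hydroxyphenyl stands in place of 3-hydroxyphenyl on an aromatic carbon next to the ring nitrogen, so the two compounds have the same atoms, joined differently.

Among the measured compounds shown here, no measured step makes this exchange. All three instead swap the thiophen-3-yl, pyridin-4-yl or 3-hydroxyphenyl group at a different place on the shared core, so they offer only a rough guide. Even across those different groups, the largest movement was the modest 2.2-fold lower number from compound 2 to compound 3 (0.33 log units; beyond the scatter). A similarly small change is therefore expected in this assay, estimated as a 1.1-fold lower number from compound 1 to compound 4 (0.03 log units; within the scatter), and the data point to no clear direction. For compound 4 the estimated value is 13000 nM, with an expected range from 5500 nM to 30000 nM.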

Compound 4, half-maximal inhibitory concentration: 17300 nM
For compound 4 the middle estimate is 1.3-fold (0.12 log units) below the measured one, within the range that was stated.
By their numbers in this assay, from the lowest: compounds 3, 1, 4 and 2 (each within the scatter of the next, the first and the last beyond it).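

In this assay, putting 4-hydroxyphenyl in place of 3-hydroxyphenyl on the aromatic carbon next to the ring nitrogen gives a 1.3-fold higher number from compound 1 to compound 4 (0.10 log units; within the scatter), so these two arrangements of the same atoms cannot be told apart here. Among the compounds shown here, this is the first measured exchange at this place, since the earlier steps all changed the group at a different place on the shared core, and it shows that the two hydroxyphenyl groups are interchangeable in this one setting, with thiophen-3-yl as the neighbouring group. Nothing available explains why the two compounds read alike, and with numbers this high, a level result says little beyond the fact that neither arrangement stands out.

The compounds shown leave open whether the hydroxyl matters at all at this place, which a methoxy group in its stead, or an amine or a carboxylic acid on the same phenyl ring, would help to settle. They also leave open whether the two hydroxyphenyl groups would stay level with pyridin-4-yl in place of thiophen-3-yl on the shared core.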